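The compounds below may be only part of what the source reports. "The series", "measured", "known", "first", "only" and "open" are said of these compounds alone.

Compound 1, `O=C1c2ccccc2N(Cc2ccccc2)S(=O)(=O)N1COCc1ccccc1`, reaches in a functional assay on HEL cells (Homo sapiens) (a lower number here means that less compound is tolerated, a higher number that more compound is tolerated), only the limit > 40 ug/mL.
Compound 2, `C#CCOCN1C(=O)c2ccccc2NS1(=O)=O`, gives in this assay a value of 169 ug/mL.
Compound 3, `CCCOCN1c2ccccc2C(=O)NS1(=O)=O`, reaches in this assay only the limit > 50 ug/mL.

Compound 3 thus stands at the limit of > 50 ug/mL in this assay, at which 1 of the 3 values shown sits, a limit rather than a number. Compound 1 likewise stands at the limit of > 40 ug/mL in this assay, at which 1 of the 3 values shown sits. For the measured compounds named here, only compound 2 gives a measured number, so no step between measured compounds can be sized.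

Compound 4, `O=C1NS(=O)(=O)N(COCCO)c2ccccc21`, differs from compound 3 by hydroxy in place of methyl on a saturated chain carbon, two bonds along the chain from an oxygen on a saturated carbon. Going by the values given here, with no measured step to lean on, the expected change in this assay is small, at most a shift toward more compound being tolerated, and it may well stay within the scatter. Compound 4 is therefore expected to give about 65 ug/mL, between 25 ug/mL and 170 ug/mL, which is an estimated step that the limit leaves unreadable from compound 3 to compound 4.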

Compound 4, half-maximal cytotoxic concentration: 112 ug/mL
Estimate against measurement, compound 4: 1.7-fold (0.24 log units) below; low and high end bracket the measured number.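

The change from compound 3 to compound 4 cannot be sized, because compound 3 gives a limit and not a number: the limit of > 50 ug/mL in this assay, at which 1 of the 4 values shown sits.
As far as these compounds go, how far hydroxy in place of methyl shifts the result in this assay remains open.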